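The source may hold more compounds than are shown below. What is called first, only, known or untested is meant among the compounds shown, and "the series" means these compounds.

Measured in a functional assay on HeLa cells (Homo sapiens) for inhibition, read by CCK-8 assay, with a stated time of 48 h; on this read-out lower numbers stand for stronger inhibition and higher numbers for weaker inhibition:
Compound 1 `Cc1ccc(C2=NN(C3=NC(=O)CS3)C(c3ccc4ccccc4c3)C2)cc1`: 1760 nM
Compound 2 `Fc1ccc(C2=NN(C3=NC(c4ccccc4)CS3)C(c3ccc4ccccc4c3)C2)cc1`: 9730 nM
Compound 3 `O=C1CSC(N2N=C(c3ccc(F)cc3)CC2c2ccc3ccccc3c2)=N1`: 9170 nM

Compound 3 stands with compound 2 at the weak end of these numbers, and the gap between them is only a 1.1-fold lower number from compound 2 to compound 3 (0.03 log units; within the scatter). Compound 4 `O=C1CSC(N2N=C(c3ccc(Cl)cc3)CC2c2ccc3ccccc3c2)=N1` differs from compound 3 in one place: chloro in place of fluoro on an aromatic carbon. The step that bears most directly on this is a 5.2-fold higher number from compound 1 to compound 3 (0.72 log units; beyond the scatter), where fluoro replaces methyl at that same place. The other step changes a different part of the molecule, so it says little here. One step cannot show where chloro will fall, so a modest move towards a lower number in this assay is expected, smaller than that fluoro-for-methyl step. The expected change is a 1.8-fold lower number from compound 3 to compound 4 (0.26 log units; within the scatter). The estimate for compound 4 is 5000 nM, with a range of 1800 nM to 12000 nM.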

Compound 4, half-maximal inhibitory concentration: 6320 nM
Compound 4: middle estimate off by 1.3-fold (0.10 log units), on the low side, and the stated range covers the measured number.
By their numbers in this assay, from the lowest: compound 1; then compounds 4, 3 and 2 (each within the scatter of the next).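

Swapping the halogen on the 4-fluorophenyl group barely registers: a 1.5-fold lower number from compound 3 to compound 4 (0.16 log units; within the scatter) stays within the scatter, so in this assay chloro and fluoro cannot be told apart at this place. Methyl does stand apart from chloro as well as from fluoro, since a 3.6-fold higher number from compound 1 to compound 4 (0.56 log units; beyond the scatter) lies beyond the scatter and so does a 5.2-fold higher number from compound 1 to compound 3 (0.72 log units; beyond the scatter) in the same direction. Nothing measured here explains this difference. Still open, going by these compounds, is whether methyl's lower number extends to other groups at this place, such as methoxy, an amine or a carboxylic acid.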